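A methylurea in place of the glycinamide on the amine

The source may hold more compounds than are shown below. What is called first, only, known or untested is meant among the compounds shown, and "the series" means these compounds.

Measured compounds:
compound 1, `CNS(=O)(=O)NC[C@@H]1CCCc2cc(S(=O)(=O)c3cccc(F)c3)ccc21`: 1 nM
compound 2, `NCC(=O)NC[C@@H]1CCCc2cc(S(=O)(=O)c3cccc(F)c3)ccc21`: 0.316 nM

In an assay on isolated protein for displacement of a labelled ligand from 5-hydroxytryptamine receptor 6 (Homo sapiens) (on this read-out lower numbers stand for stronger inhibition and higher numbers for weaker inhibition), compound 2 gives 0.316 nM, the lowest of the two numbers shown. Compound 1 gives 1 nM, and the step between them is a 3.2-fold lower number from compound 1 to compound 2 (0.50 log units; beyond the scatter). Compound 3, `CNC(=O)NC[C@@H]1CCCc2cc(S(=O)(=O)c3cccc(F)c3)ccc21`, differs from compound 2 by methylamino in place of aminomethyl on a carbonyl carbon. No measured step matches this exchange; the single step shown concerns a different group on the same amine nitrogen and was modest. A small movement back toward compound 1 is therefore expected, a 1.9-fold higher number from compound 2 to compound 3 (0.28 log units; within the scatter). Compound 3 is estimated at 0.6 nM, within 0.25 nM to 1.6 nM.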

Compound 3, inhibition constant: 0.398 nM
Compound 3: the middle estimate sits 1.5-fold (0.18 log units) above what was measured; low and high end bracket the measured number.
By their numbers in this assay, from the lowest: compounds 2 and 3 (each within the scatter of the next); then compound 1.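

In this assay the methylurea of compound 3 and the glycinamide of compound 2 cannot be told apart, so exchanging aminomethyl for methylamino on this carbonyl carbon leaves the number within the scatter (a 1.3-fold higher number from compound 2 to compound 3 (0.10 log units; within the scatter)). Methylcarbamoyl in place of methylsulfamoyl on the amine nitrogen also gives a step beyond the scatter (a 2.5-fold lower number from compound 1 to compound 3 (0.40 log units; beyond the scatter)), so compound 1 now stands apart from both carbonyl compounds. No evidence is available to explain these results. As far as these compounds go, whether an ethylamino or a dimethylamino group on the carbonyl carbon would keep the number in this range remains open.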